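This account rests on a few compounds, and the source may have more. Where it says the series, first, only, none or still open, it means among the compounds named here.

The series shares one core, shown in compound 1 `O=C1/C(=C\c2ccccc2)N=C(c2ccccc2)N1c1ccc2oc(-c3ccccc3)cc(=O)c2c1`, which carries an unsubstituted phenyl on the double-bonded chain carbon. In a functional assay on MDA-MB-435 cells (Homo sapiens) for inhibition, read by MTT assay (on this read-out higher numbers stand for weaker inhibition and lower numbers for stronger inhibition), compound 1 gives 24.3 ug/mL. Compound 2 `COc1ccc(/C=C2/N=C(c3ccccc3)N(c3ccc4oc(-c5ccccc5)cc(=O)c4c3)C2=O)cc1` differs only in bearing a methoxy on that phenyl, and in this assay compound 2 gives 18.5 ug/mL. The step of a 1.3-fold lower number from compound 1 to compound 2 (0.12 log units; within the scatter) is within the scatter, so on the two numbers shown compound 2 stands alongside compound 1 rather than apart from it.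

Compound 3 `O=C1/C(=C\c2ccc(Cl)c(Cl)c2)N=C(c2ccccc2)N1c1ccc2oc(-c3ccccc3)cc(=O)c2c1` is the next member; the change from compound 2 is 3,4-dichlorophenyl in place of 4-methoxyphenyl on a double-bonded chain carbon bound to a double-bonded ring carbon. Among the compounds with values here, the only measured step that touches this part of the molecule is a 1.3-fold lower number from compound 1 to compound 2 (0.12 log units; within the scatter), and it showed no movement beyond the scatter. Within the data shown here, no measured step tells how the 3,4-dichlorophenyl itself behaves here. On that basis, the step from compound 2 to compound 3 is expected to be a 1.0-fold lower number from compound 2 to compound 3 (0.01 log units; within the scatter), that is, no movement beyond the scatter. Compound 3 is therefore estimated at 18 ug/mL in this assay, with a range from 7 ug/mL to 45 ug/mL.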

Compound 3, half-maximal inhibitory concentration: 16.9 ug/mL
Compound 3: middle estimate off by 1.1-fold (0.03 log units), on the high side; low and high end bracket the measured number.
By their numbers in this assay, from the lowest: compounds 3, 2 and 1 (each within the scatter of the next).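

The change at this position now reaches beyond a single added methoxy: 3,4-dichlorophenyl enters with two chlorines and no hydrogen-bond acceptor in place of 4-methoxyphenyl, which has one, and in this assay the result is only a 1.1-fold lower number from compound 2 to compound 3 (0.04 log units; within the scatter). Measured against the unsubstituted phenyl of compound 1, the same group gives a 1.4-fold lower number from compound 1 to compound 3 (0.16 log units; within the scatter), so this read-out does not separate any of the three aromatic groups placed on the double-bonded chain carbon bound to a double-bonded ring carbon. Nothing available explains this flat result, and no separate measurement bears on it.

The three compounds share the phenyl groups elsewhere on the core and differ only in substituted or unsubstituted phenyl at this one place, so they leave open whether any change at this position can move the number beyond the scatter, for example an amine or a carboxylic acid on the ring, or a longer chain in place of the ring. They also leave open how the read-out would respond to a change at the other phenyl groups of the shared core.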